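Changing the Aromatic Group on a Shared Core

A few compounds are considered here, and "the series" means these few. Any claim that something is new, unique, unknown or untested is made for them only; others in the source may bear on it.

Compound 1 `CC1=CC[C@H]2[C@H](CC[C@]2(C)O)C(C)(C)[C@@H]1CC[C@H]1[C@]2(C)CC[C@H](OC(=O)c3ccc(Cl)cc3)C(C)(C)O[C@H]2CC[C@@]1(C)O` gives 24100 nM
Compound 2 `CC1=CC[C@H]2[C@H](CC[C@]2(C)O)C(C)(C)[C@@H]1CC[C@H]1[C@]2(C)CC[C@H](OC(=O)NCc3ccccc3)C(C)(C)O[C@H]2CC[C@@]1(C)O` gives 24500 nM
Compound 3 `COc1ccc(C(=O)O[C@H]2CC[C@]3(C)[C@H](CC[C@@](C)(O)[C@H]3CC[C@@H]3C(C)=CC[C@H]4[C@H](CC[C@]4(C)O)C3(C)C)OC2(C)C)cc1` gives 41700 nM

In a functional assay on MCF7 cells (Homo sapiens) for antiproliferative activity, read by MTT assay, with a stated time of 72 h (on this read-out lower numbers stand for stronger inhibition and higher numbers for weaker inhibition), compound 3 gives 41700 nM and so sits within the scatter of the other two, as a 1.7-fold higher number from compound 1 to compound 3 (0.24 log units; within the scatter) and a 1.7-fold higher number from compound 2 to compound 3 (0.23 log units; within the scatter) both show. Compound 4 `CC1=CC[C@H]2[C@H](CC[C@]2(C)O)C(C)(C)[C@@H]1CC[C@H]1[C@]2(C)CC[C@H](OC(=O)c3cccc(C(F)(F)F)c3)C(C)(C)O[C@H]2CC[C@@]1(C)O` keeps the shared core and changes one group, counted as 3-(trifluoromethyl)phenyl in place of 4-methoxyphenyl on a carbonyl carbon in all: 3-(trifluoromethyl)phenyl in place of 4-methoxyphenyl on a carbonyl carbon.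

Among the compounds with values here, no measured pair makes this exact swap. The closest guide is methoxy in place of chloro on an aromatic carbon, which gave a 1.7-fold higher number from compound 1 to compound 3 (0.24 log units; within the scatter) as its step. A larger change, benzylamino in place of 4-chlorophenyl on a carbonyl carbon, gave a 1.0-fold higher number from compound 1 to compound 2 (0.01 log units; within the scatter) as its step. All of these steps lie within the scatter, and none beyond it is expected in this assay for compound 4 either. The expected step is a 1.5-fold lower number from compound 3 to compound 4 (0.17 log units; within the scatter) on this estimate. For compound 4 the estimated value is 28000 nM with an expected range from 14000 nM to 50000 nM around it.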

Compound 4, half-maximal inhibitory concentration: 37900 nM
Beside the measured number, compound 4's estimate is 1.4-fold (0.13 log units) below it, within the range that was stated.
By their numbers in this assay, from the lowest: compounds 1, 2, 4 and 3 (each within the scatter of the next).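

In this assay, a ring with a trifluoromethyl group, fluorine in place of oxygen and no hydrogen-bond acceptor still leaves the number where the 4-methoxyphenyl compound had it (a 1.1-fold lower number from compound 3 to compound 4 (0.04 log units; within the scatter)). The same holds against the benzylamino and 4-chlorophenyl compounds (a 1.5-fold higher number from compound 2 to compound 4 (0.19 log units; within the scatter); a 1.6-fold higher number from compound 1 to compound 4 (0.20 log units; within the scatter)), so all four groups on this carbonyl carbon remain within the scatter of one another, and this read-out does not separate them. Nothing measured here offers an explanation for this flat picture.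

All four compounds carry an aromatic ring at this place. On these data alone, it remains open whether a group without such a ring, such as an amine, a carboxylic acid or a longer alkyl chain, would move the number beyond the scatter.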